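A Second Methoxy on the Aryl Ring of Compound 2

The source may report more compounds than this note shows. Statements on the series, on what has been measured and on what is new or still open speak of the compounds shown alone.

Compound 1 `O=C(Nc1nc2ccc(Cl)cc2s1)c1cc(-c2ccc(F)cc2)n2nc(-c3ccccc3)cc2n1`: in a functional assay on A549 cells (Homo sapiens) for cytotoxicity, read by MTT assay, with a stated time of 48 h (on this read-out higher numbers stand for weaker inhibition and lower numbers for stronger inhibition), compound 1 gives 6600 nM.
Compound 2 `COc1ccc(-c2cc(C(=O)Nc3nc4ccc(Cl)cc4s3)nc3cc(-c4ccccc4)nn23)cc1`: in this assay compound 2 gives 3090 nM.

Going by the values given here, compound 2 holds the lowest of the two numbers, and its only neighbour, compound 1, sits one step away: a 2.1-fold lower number from compound 1 to compound 2 (0.33 log units; beyond the scatter). Compound 3 `COc1ccc(-c2cc(C(=O)Nc3nc4ccc(Cl)cc4s3)nc3cc(-c4ccccc4)nn23)cc1OC` has not yet been measured; it differs from compound 2 by methoxy in place of hydrogen on an aromatic carbon. Among the compounds with values here, no measured step makes this same change. Within the data shown here, the single step available, a 2.1-fold lower number from compound 1 to compound 2 (0.33 log units; beyond the scatter), swaps one group for another on one aromatic carbon and is modest, whereas here a group is added where only hydrogen stood, so it gives only weak guidance. The expected outcome is a number close to that of compound 2, perhaps slightly lower, and the expected step is a 1.2-fold lower number from compound 2 to compound 3 (0.09 log units; within the scatter). Compound 3 is therefore estimated at 2500 nM in this assay, with a range from 1000 nM to 7000 nM.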

Compound 3, half-maximal inhibitory concentration: 6160 nM
Compound 3: middle estimate off by 2.5-fold (0.39 log units), on the low side, within the range that was stated.
By their numbers in this assay, from the lowest: compounds 2, 3 and 1 (each within the scatter of the next, the first and the last beyond it).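

In this assay, adding a second methoxy to give the 3,4-dimethoxyphenyl ring produces a 2.0-fold higher number from compound 2 to compound 3 (0.30 log units; within the scatter), so this added group has no effect here that can be told apart from the spread of repeated measurements. The 3,4-dimethoxyphenyl ring also cannot be separated from the 4-fluorophenyl ring, as shown by a 1.1-fold lower number from compound 1 to compound 3 (0.03 log units; within the scatter), even though compound 1 and compound 2 do differ beyond the scatter, which leaves compound 3 unresolved from both of its neighbours. No measurement shown here explains this result.

As far as these compounds go, it remains open whether an amine or a carboxylic acid on this same aromatic carbon would move the number beyond the scatter from compound 2. A longer chain, such as ethoxy, in place of the added methoxy is equally unresolved.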